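This account rests on a few compounds, and the source may have more. Where it says the series, first, only, none or still open, it means among the compounds named here.

Measured so far in an ADME assay on Vero cells (Chlorocebus sabaeus) for cytotoxicity, read by resazurin assay, with a stated time of 3 days; a higher number here means a weaker inhibitor, a lower number a stronger inhibitor:
compound 1 `CN(C)c1cc2[nH]c(C3CCCCC3)nc2cc1NC(=O)c1ccc(Br)cc1`: > 100 ug/mL
compound 2 `CCCCOC(=O)Nc1cc2nc(C3CCCCC3)[nH]c2cc1N(C)C`: > 100 ug/mL
compound 3 `CCCOCC(=O)Nc1cc2nc(C3CCCCC3)[nH]c2cc1N(C)C`: < 50 ug/mL

Compound 2 gives only a limit in this assay, > 100 ug/mL, and so stands at the limit of > 100 ug/mL in this assay, at which 2 of the 3 values shown sit. Compound 1 likewise gives a limit, > 100 ug/mL. Compound 3 gives a limit as well, < 50 ug/mL, which is the limit of < 50 ug/mL in this assay, at which 1 of the 3 values shown sits. Of the measured steps, a step that the two limits leave unreadable from compound 1 to compound 2 cannot be read, while an at least 2.0-fold lower number from compound 2 to compound 3 (0.30 log units; that floor lies within the scatter) and an at least 2.0-fold lower number from compound 1 to compound 3 (0.30 log units; that floor lies within the scatter) are floors only, each within the scatter. All three steps alter the group on the carbonyl carbon.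

Compound 4 `CCCCOC(=O)Nc1cc2nc(C3CCCCC3)[nH]c2cc1N(C)CCN(C)C` differs from compound 2 by (dimethylamino)methyl in place of hydrogen on a saturated chain carbon bound to a nitrogen on an aromatic ring. No measured step touches this position, so nothing shown bears on it directly. The expectation therefore rests on compound 2 alone at > 100 ug/mL; compound 4 is expected to give 100 ug/mL, between 40 ug/mL and 250 ug/mL. The step of a number no higher from compound 2 to compound 4 (the limit leaves the size open) is thus estimated as none beyond the scatter, most likely again a limit.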

Compound 4, half-maximal inhibitory concentration: > 100 ug/mL
Compound 4: a limit, no number; the forecaster's own chance of this, stated with the estimate: 60%; the middle value sits exactly at the limit.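

In this assay compound 4 gives only a limit, > 100 ug/mL. Compound 2 also gives a limit, > 100 ug/mL, so no step can be read between compound 2 and compound 4. Still open, as far as these compounds go, is whether (dimethylamino)methyl in place of hydrogen on a saturated chain carbon bound to a nitrogen on an aromatic ring shifts the value at all.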